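Chloro for Nitro on the Benzyl Arm

The source may report more compounds than this note shows. Statements on the series, on what has been measured and on what is new or still open speak of the compounds shown alone.

Of the compounds shown here, three built on one shared core have been measured in a functional assay on the whole organism (strain C57Bl/6) for inhibition, with Mus musculus as the target, with a stated time of 180 min, at 48 degrees C; on this read-out lower numbers stand for an effect already at smaller amounts and higher numbers for an effect only at larger amounts of compound. Compound 2 `COc1ccc(Cn2c(NCCNC(=N)N)nc(=O)n(Cc3ccc([N+](=O)[O-])cc3)c2=O)cc1` gives 0.048 nM in this assay. Compound 1 `COc1ccc(Cn2c(=O)nc(NCCNC(=N)N)n(Cc3ccc(I)cc3)c2=O)cc1` gives 0.039 nM, a number that lies within the usual scatter of the number for compound 2, so the two cannot be told apart. Compound 3 `Cc1ccc(Cn2c(=O)nc(NCCNC(=N)N)n(Cc3ccc(Cl)c(Cl)c3)c2=O)cc1` gives 0.0051 nM, which sits well beyond the scatter on the lower side. Compound 2 therefore stands at the upper end of the three, with compound 1 keeping it company.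

The next compound, compound 4 `COc1ccc(Cn2c(NCCNC(=N)N)nc(=O)n(Cc3ccc(Cl)cc3)c2=O)cc1`, has not yet been measured. It differs from compound 2 in one place: chloro in place of nitro on an aromatic carbon. Among the compounds with values here, no measured pair shows exactly this exchange, so the size of the step has to be guessed. Compound 1 also carries a halogen on one of its benzyl rings and gives 0.039 nM, close to compound 2, which suggests that a halogen in this role leaves the number roughly where it is. The step is expected to be modest, a 1.2-fold lower number from compound 2 to compound 4 (0.08 log units; within the scatter), pointing slightly downward or not beyond the scatter at all. For compound 4 the estimated value in this assay is 0.04 nM, with a range from 0.015 nM to 0.1 nM.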

Compound 4, half-maximal effective concentration: 0.004 nM
Estimate against measurement, compound 4: 10-fold (1.00 log units) above; measured number below the stated range.
By their numbers in this assay, from the lowest: compounds 4 and 3 (each within the scatter of the next); then compounds 1 and 2 (each within the scatter of the next).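

Exchanging 4-nitrobenzyl for 4-chlorobenzyl, with the rest of the molecule unchanged, gives in this assay a 12-fold lower number from compound 2 to compound 4 (1.08 log units; beyond the scatter), a large step. Within the data shown here, this is the first comparison here between two compounds that differ in one place only, and it shows that the group para to a large group on this aromatic ring can by itself move the number well beyond the scatter; compounds 1, 2 and 3 differ in more than one place, so they could not separate the effect of this position from that of other changes. The data shown give no measured reason for the size of this step.

The compounds shown leave open how an amine, a carboxylic acid or a trifluoromethyl group at this same place would compare with nitro and chloro. They also leave open whether the exchange of nitro for chloro would bring a step of similar size on the core of compound 3, or in a compound with a longer chain in place of the one carrying the guanidine.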